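The source may report more compounds than this note shows. Statements on the series, on what has been measured and on what is new or still open speak of the compounds shown alone.

Measured compounds in a functional assay on MCF7 cells (Homo sapiens) for antiproliferative activity, read by sulforhodamine B assay, with a stated time of 48 h; a lower number here means a stronger inhibitor, a higher number a weaker inhibitor:
compound 1 `CCCCCC(=O)Nc1ccc(S(=O)(=O)Oc2ccccc2I)cc1` gives 10000 nM
compound 2 `CC(C)C(=O)Nc1ccc(S(=O)(=O)Oc2ccccc2I)cc1` gives 8100 nM
compound 3 `CC(C)(C)C(=O)Nc1ccc(S(=O)(=O)Oc2ccccc2I)cc1` gives 6600 nM

Compound 3 holds the lowest of the three numbers, but its gaps to the others are small: a 1.5-fold lower number from compound 1 to compound 3 (0.18 log units; within the scatter) and a 1.2-fold lower number from compound 2 to compound 3 (0.09 log units; within the scatter) both fall within the scatter, as does a 1.2-fold lower number from compound 1 to compound 2 (0.09 log units; within the scatter). Across the three acyl groups tried on the shared core, this assay has so far not moved beyond repeat variation.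

Compound 4 `O=C(CCl)Nc1ccc(S(=O)(=O)Oc2ccccc2I)cc1` carries the change (chloromethyl in place of tert-butyl on a carbonyl carbon). The measured steps all swap one saturated alkyl for another on that carbonyl carbon; none introduces a chlorine, so they bear on this step only loosely. On their evidence, no step beyond the scatter is expected, with the halogen left as an open question. Compound 4 is expected at 5000 nM (range 1500 nM to 15000 nM), a step of a 1.3-fold lower number from compound 3 to compound 4 (0.12 log units; within the scatter).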

Compound 4, half-maximal inhibitory concentration: 2500 nM
Beside the measured number, compound 4's estimate is 2.0-fold (0.30 log units) above it, within the range that was stated.
By their numbers in this assay, from the lowest: compound 4; then compounds 3, 2 and 1 (each within the scatter of the next).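

Chloromethyl on the carbonyl carbon moves this assay beyond the scatter for the first time at this position, with modest steps: a 2.6-fold lower number from compound 3 to compound 4 (0.42 log units; beyond the scatter) and a 3.2-fold lower number from compound 2 to compound 4 (0.51 log units; beyond the scatter) and a 4.0-fold lower number from compound 1 to compound 4 (0.60 log units; beyond the scatter) against each alkyl group tried. This position is therefore not indifferent to the acyl group, which the three alkyl groups alone did not show. No measurement at hand accounts for the shift.

Going by these compounds, whether the chlorine itself is what counts remains open. Methyl, bromomethyl or aminomethyl on the carbonyl carbon would test this.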